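The source may report more compounds than this note shows. Statements on the series, on what has been measured and on what is new or still open speak of the compounds shown alone.

Measured compounds in a functional assay for antagonist activity at integrin alpha-5/beta-1 (Homo sapiens), read by ELISA; on this read-out lower numbers stand for stronger inhibition and higher numbers for weaker inhibition:
- compound 1, `O=C(NC[C@@H](C(=O)O)S(=O)(=O)c1ccccc1)C1=NOC2(CCC(CNc3ncc[nH]3)CC2)C1`, gives 4700 nM
- compound 2, `Cc1cc(C)c(S(=O)(=O)[C@@H](CNC(=O)C2=NOC3(CCC(CNc4ncc[nH]4)CC3)C2)C(=O)O)c(C)c1`, gives 1500 nM

Compound 2 stands at the lowest of the two numbers; its nearest neighbour is compound 1, and the step of a 3.1-fold lower number from compound 1 to compound 2 (0.50 log units; beyond the scatter) separates them. Going by the values given here, the only measured step, however, concerns the aryl group on the sulfonyl sulfur and leaves the amine end of the core untouched. Compound 3, `Cc1cc(C)c(S(=O)(=O)[C@@H](CNC(=O)C2=NOC3(CCC(CNc4nc5ccccc5[nH]4)CC3)C2)C(=O)O)c(C)c1`, differs from compound 2 at that other end: 1H-benzimidazol-2-yl in place of 1H-imidazol-2-yl on an amine nitrogen. Among the compounds with values here, no measured pair in this set shows how this assay answers a change at the amine nitrogen, so the measured step gives no direct guide. With nothing to point either way, the step of a 1.3-fold lower number from compound 2 to compound 3 (0.10 log units; within the scatter) is expected to stay small, most likely within the scatter, and compound 3 is estimated to give 1200 nM in this assay, with a plausible range from 300 nM to 4500 nM.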

Compound 3, half-maximal inhibitory concentration: 170 nM
Beside the measured number, compound 3's estimate is 7.1-fold (0.85 log units) above it; the whole stated range lies above it.
By their numbers in this assay, from the lowest: compound 3; then compound 2; then compound 1.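

In this assay, the replacement of 1H-imidazol-2-yl by 1H-benzimidazol-2-yl on the amine nitrogen gives an 8.8-fold lower number from compound 2 to compound 3 (0.95 log units; beyond the scatter), which shows that this end of the molecule also registers in the read-out, and not only the aryl group on the sulfonyl sulfur. The entering group adds a six-membered aromatic ring of carbon only, while the counts of hydrogen-bond donors and acceptors stay the same. Nothing available here accounts for why this change goes with the lower number.

The compounds shown leave open whether the same replacement would give a similar step with the phenyl group of compound 1 on the sulfonyl sulfur. Also open, from the compounds shown here alone, is how a pyridin-2-yl group on the amine nitrogen, or a fluorine or methyl group on the added ring, would compare with compound 3.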